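The source may report more compounds than this note shows. Statements on the series, on what has been measured and on what is new or still open speak of the compounds shown alone.

Compound 1 `CC(C)C(c1ccc(-c2ccc3cccc(F)c3c2)[nH]c1=O)N1CCCCC1=O`: 0.102 h
Compound 2 `CC(C)C(/C=C1/CCNC1=O)c1ccc(-c2ccc3cccc(F)c3c2)[nH]c1=O`: 0.06 h

Among the measured compounds shown here, in an ADME assay on microsomes from liver (Rattus norvegicus) for metabolic stability (a higher number here means that the compound lasts longer, a lower number that the compound disappears faster), compound 2 gives 0.06 h, the lower of the two numbers measured so far, while compound 1 gives 0.102 h. For the measured compounds named here, the one measured step, a 1.7-fold lower number from compound 1 to compound 2 (0.23 log units; within the scatter), is within the scatter, so the two compounds cannot be told apart on these numbers; both disappear quickly.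

Compound 3 `CC(C)C(c1ncco1)c1ccc(-c2ccc3cccc(F)c3c2)[nH]c1=O` differs from compound 2 at the same position that was changed in that step: a group of 5 heavy atoms (3 carbon, 1 nitrogen, 1 oxygen; one five-membered aromatic ring with 2 hetero atoms) in place of a group of 7 heavy atoms (5 carbon, 1 nitrogen, 1 oxygen; one five-membered non-aromatic ring with 1 hetero atom), on a saturated chain carbon bound to an aromatic carbon and a saturated chain carbon. Going by the values given here, the measured step exchanged one non-aromatic ring for another of a different size; the change to compound 3 puts an aromatic ring with two hetero atoms in place of a non-aromatic ring, a kind of change that no measured pair covers. Among the compounds with values here, the only available step bears on it loosely and was within the scatter, so the expectation is a step of no more than the scatter in this assay, estimated as a 1.3-fold higher number from compound 2 to compound 3 (0.12 log units; within the scatter). Compound 3 is therefore expected to give about 0.08 h, with a likely range from 0.03 h to 0.25 h.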

Compound 3, half-life: 0.0983 h
Estimate against measurement, compound 3: 1.2-fold (0.09 log units) below, and the stated range covers the measured number.
By their numbers in this assay, from the lowest: compounds 2, 3 and 1 (each within the scatter of the next).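

Replacing the five-membered non-aromatic ring with 1,3-oxazol-2-yl, the first aromatic ring at this position, gives a 1.6-fold higher number from compound 2 to compound 3 (0.21 log units; within the scatter) in this assay, and replacing 2-oxopiperidin-1-yl with the same group gives a 1.0-fold lower number from compound 1 to compound 3 (0.02 log units; within the scatter). Both steps lie within the scatter, so on the saturated chain carbon bound to an aromatic carbon and a saturated chain carbon, compounds 1, 2 and 3 cannot be told apart, even though an aromatic ring with 2 hetero atoms has entered in place of a non-aromatic ring and the group has become smaller by count of heavy atoms. No separate measurement is available that would explain these numbers.

The compounds shown leave open whether a quite different kind of group at this position, such as an amine, a carboxylic acid or a plain longer carbon chain, would give a number beyond the scatter. They also leave open whether a change elsewhere on the shared core, such as chlorine in place of the fluorine, would move the number further than any of the ring exchanges seen here.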